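This account rests on a few compounds, and the source may have more. Where it says the series, first, only, none or still open, it means among the compounds named here.

Measured so far:
compound 1 `COc1ccnc(N2CCN(c3nc(N)c4cc(OC)c(OC)cc4n3)CC2)n1` — 0.19 nM
compound 2 `COc1cc2nc(N3CCN(c4nccc(C)n4)CC3)nc(N)c2cc1OC` — 0.92 nM

Both numbers come from an assay on brain for binding affinity to Adrenergic receptor alpha-1 (Rattus norvegicus); a lower number here means a stronger inhibitor, a higher number a weaker inhibitor. Within the data shown here, compound 2 holds the higher of the two; the nearest point is compound 1, and the only measured step is a 4.8-fold higher number from compound 1 to compound 2 (0.69 log units; beyond the scatter), a methyl in place of methoxy on an aromatic carbon of the shared core.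

Compound 3 `COc1cc2nc(N3CCN(c4nccc(-c5ccccc5)n4)CC3)nc(N)c2cc1OC` is not yet measured. It differs from compound 2 by phenyl in place of methyl on an aromatic carbon. Among the measured compounds shown here, the step from compound 1 to compound 2 touches the same carbon, but it exchanged methoxy for methyl, not methyl for phenyl, so it is only an indirect guide; no measured pair exchanges a small alkyl for an aromatic ring here. With nothing firmer to go on, the step from compound 2 to compound 3 is expected to be small, a 1.6-fold higher number from compound 2 to compound 3 (0.21 log units; within the scatter), possibly not beyond the scatter. Compound 3 is therefore estimated at 1.5 nM, within a range of 0.4 nM to 6 nM.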

Compound 3, inhibition constant: 1.66 nM
Estimate against measurement, compound 3: 1.1-fold (0.04 log units) below; the range from low to high includes it.
By their numbers in this assay, from the lowest: compound 1; then compounds 2 and 3 (each within the scatter of the next).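

In this assay a single carbon and a whole six-membered aromatic ring at this aromatic carbon next to the ring nitrogen are not told apart: the exchange of methyl for phenyl gives a 1.8-fold higher number from compound 2 to compound 3 (0.26 log units; within the scatter) and so compound 2 and compound 3 stand together despite the difference in size. Methoxy is now the only group of the three set apart, with an 8.7-fold higher number from compound 1 to compound 3 (0.94 log units; beyond the scatter) alongside a 4.8-fold higher number from compound 1 to compound 2 (0.69 log units; beyond the scatter) and both steps beyond the scatter. No measurement at hand explains either the closeness of methyl and phenyl or the separate standing of methoxy.

Going by these compounds, whether the same closeness holds for a longer chain such as butyl, a saturated ring such as cyclohexyl or an amine at this carbon remains open. Also open, on these data alone, is whether ethoxy stands with methoxy.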